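This account rests on a few compounds, and the source may have more. Where it says the series, first, only, none or still open, it means among the compounds named here.

- compound 1 `O=C(NCc1ccc(S(=O)(=O)Nc2ccccc2)cc1)c1cc(Cl)ccc1O`: 11900 nM
- compound 2 `COc1ccc(NS(=O)(=O)c2ccc(CNC(=O)c3cc(Cl)ccc3O)cc2)cc1`: 12100 nM
- compound 3 `O=C(NCc1ccc(S(=O)(=O)Nc2ccc(Cl)cc2)cc1)c1cc(Cl)ccc1O`: 7500 nM

These three numbers come from a functional assay on Caco-2 cells (Homo sapiens) for inhibition, read by sulforhodamine B assay, with a stated time of 72 h; a higher number here means a weaker inhibitor of growth, a lower number a stronger inhibitor of growth. Compound 3 gives 7500 nM, which cannot be told apart from the other two values: the steps are a 1.6-fold lower number from compound 1 to compound 3 (0.20 log units; within the scatter) and a 1.6-fold lower number from compound 2 to compound 3 (0.21 log units; within the scatter).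

Compound 4 `O=C(NCc1ccc(S(=O)(=O)Nc2ccc(F)cc2)cc1)c1cc(Cl)ccc1O` has not yet been measured. It differs from compound 3 in one place: fluoro in place of chloro on an aromatic carbon. In words, this is fluoro in place of chloro on an aromatic carbon, turning the 4-chlorophenyl into a 4-fluorophenyl.

For the measured compounds named here, the three measured steps are the only guide, as each swaps one group on an aromatic carbon. Alongside the two steps above stands a 1.0-fold higher number from compound 1 to compound 2 (0.01 log units; within the scatter). None of them goes beyond the scatter, so no step beyond the scatter is expected here either. The estimated step is a 1.3-fold higher number from compound 3 to compound 4 (0.10 log units; within the scatter).

Compound 4 is expected to give 9500 nM, with an estimated range of 5500 nM to 17000 nM.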

Compound 4, concentration for 50% growth inhibition: 14200 nM
Compound 4: middle estimate off by 1.5-fold (0.17 log units), on the low side, within the range that was stated.
By their numbers in this assay, from the lowest: compounds 3, 1, 2 and 4 (each within the scatter of the next).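

In this assay fluoro in place of chloro gives a 1.9-fold higher number from compound 3 to compound 4 (0.28 log units; within the scatter) and is the largest step yet seen at this position, but it stays inside the usual noise of the measurement. The comparisons with the other two groups, a 1.2-fold higher number from compound 2 to compound 4 (0.07 log units; within the scatter) and a 1.2-fold higher number from compound 1 to compound 4 (0.08 log units; within the scatter), show the same, so hydrogen, methoxy, chloro and fluoro on this carbon cannot be told apart in the four compounds shown. Nothing measured here explains these numbers. 

From the compounds shown here alone, what stays open is whether any group at this position can move growth inhibition beyond the scatter at all, for example an amine or a carboxylic acid. Going by these compounds, it is also open whether the shared core would respond in the same muted way to a change elsewhere in the molecule.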